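A few compounds are considered here, and "the series" means these few. Any claim that something is new, unique, unknown or untested is made for them only; others in the source may bear on it.

Measured compounds:

Compound 1, `Clc1ccc(Cn2nnc3c(Br)cccc32)cc1`, in a functional assay on cells for positive allosteric modulation of metabotropic glutamate receptor 2 (Homo sapiens), read by fluorescence and calcium flux, with a stated time of 30 min (on this read-out lower numbers stand for an effect already at smaller amounts and higher numbers for an effect only at larger amounts of compound), gives 17 nM.
Compound 2, `Brc1ccc(Cn2nnc3c(Br)cccc32)cc1`, in this assay gives 14 nM.
Compound 3, `Brc1ccc(Cn2nnc3c(Br)cccc32)cn1`, in this assay gives 210 nM.

Compounds 1 and 2 share a core and differ in one place only: chloro in place of bromo on an aromatic carbon. The step this made is a 1.2-fold higher number from compound 2 to compound 1 (0.08 log units; within the scatter), so the two values stand within the usual scatter of each other and no order between them is claimed. Compound 3 carries a different core; the difference between the two cores is not broken down here. Its value stands highest of the three, a gap to compound 1 and to compound 2 that lies beyond the scatter.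

Compound 4, `Clc1ccc(Cn2nnc3c(Br)cccc32)cn1`, is not yet measured in this assay. It differs from compound 3 in one place: chloro in place of bromo on an aromatic carbon. This is the same kind of change as that from compound 2 to compound 1, though the surroundings differ: in compound 1 the chloro sits on a six-membered aromatic ring of carbon only, para to a large group, whereas in compound 4 it sits on a six-membered aromatic ring with one nitrogen, next to the ring nitrogen, para to a large group.

The expected step from compound 3 to compound 4 in this assay is a 1.2-fold higher number from compound 3 to compound 4 (0.08 log units; within the scatter), resting on the small step of a 1.2-fold higher number from compound 2 to compound 1 (0.08 log units; within the scatter) and on the value that compound 3 gives, 210 nM. Compound 4 is therefore estimated at 250 nM, with a range of 120 nM to 520 nM.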

Compound 4, half-maximal effective concentration: 290 nM
Estimate against measurement, compound 4: 1.2-fold (0.06 log units) below; measured number inside the range.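

In this assay, chloro in place of bromo on the aromatic carbon gives a 1.4-fold higher number from compound 3 to compound 4 (0.14 log units; within the scatter) and so leaves compound 3 and compound 4 within the usual scatter of each other, with no order claimed between them. Set beside the earlier pair, the same change reads alike on the two cores: the same change on two cores in this assay, a 1.2-fold higher number (0.08 log units; within the scatter) from compound 2 to compound 1 and a 1.4-fold higher number (0.14 log units; within the scatter) from compound 3 to compound 4, 1.1-fold (0.06 log units) apart, within the scatter of two such steps. This shows that, in the two pairs at hand, the exchange of these two halogens carries from one core to the other without a step that stands out from the scatter, whether the ring holds carbon only or one nitrogen; it does not show that the same holds on any further core, or in any other assay, and two pairs give no reason why the steps agree.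

The compounds shown leave open how fluoro, methyl or a nitrile would read in the place of chloro and bromo, on either core. They also leave open what an amine or a methoxy group would give in place of the other bromo, which all four compounds carry.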